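Replacing the sulfur-linked group of compound 3

The source may report more compounds than this note shows. Statements on the series, on what has been measured and on what is new or still open speak of the compounds shown alone.

In a functional assay on the whole organism with Canis familiaris (Canis lupus familiaris) as the target (a higher number here means that more compound is needed for the effect, a lower number that less compound is needed), compound 1 `OC(CSc1[nH]cnc2ncnc1-2)CN1CCN(C(c2ccc(Br)cc2)c2ccc(Br)cc2)CC1` gives 0.31 mg/kg, compound 2 `Nc1nc(SCC(O)CN2CCN(C(c3ccc(F)cc3)c3ccc(F)cc3)CC2)c2[nH]cnc2n1` gives 0.85 mg/kg and compound 3 `Cn1cnc2c(SCC(O)CN3CCN(C(c4ccc(F)cc4)c4ccc(F)cc4)CC3)ncnc21` gives 1.9 mg/kg, the highest of the three numbers. Compound 3 therefore needs the most compound for the effect in this small set.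

The next structure is compound 4 `OC(CNc1[nH]cnc2ncnc1-2)CN1CCN(C(c2ccc(F)cc2)c2ccc(F)cc2)CC1`, and the change is a group of 10 heavy atoms (5 carbon, 5 nitrogen; one five-membered aromatic ring with 2 hetero atoms, one six-membered aromatic ring with 2 hetero atoms) in place of a group of 11 heavy atoms (6 carbon, 4 nitrogen, 1 sulfur; one five-membered aromatic ring with 2 hetero atoms, one six-membered aromatic ring with 2 hetero atoms), on a saturated chain carbon, two bonds along the chain from an oxygen on a saturated carbon. The sulfur leaves with the outgoing group, and the entering group carries more hydrogen-bond donors.

Within the data shown here, only one measured step bears on this: a 2.2-fold higher number from compound 2 to compound 3 (0.35 log units; beyond the scatter). It is modest, and it exchanges one group on a sulfur for another, so the sulfur stays in place. Among the measured compounds shown here, no measured pair shows what happens when the sulfur is lost, so that step gives only a rough guide to size and no firm direction. The expected change is therefore small, and the estimate is a 1.5-fold lower number from compound 3 to compound 4 (0.16 log units; within the scatter). The range is kept wide for that reason.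

For compound 4 the estimated value in this assay is 1.3 mg/kg, with an expected range of 0.4 mg/kg to 4.5 mg/kg.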

Compound 4, dose for half-maximal effect: 0.28 mg/kg
Compound 4: middle estimate off by 4.6-fold (0.67 log units), on the high side; the measured number lies below the stated range.
By their numbers in this assay, from the lowest: compounds 4 and 1 (each within the scatter of the next); then compound 2; then compound 3.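

At the saturated chain carbon, two bonds along the chain from an oxygen on a saturated carbon, the entering group of 10 heavy atoms (5 carbon, 5 nitrogen) lowers the number in this assay against both sulfur-bearing groups: a 6.8-fold lower number from compound 3 to compound 4 (0.83 log units; beyond the scatter), and a 3.0-fold lower number from compound 2 to compound 4 (0.48 log units; beyond the scatter). The earlier step between the two sulfur-bearing groups gave no direction for loss of the sulfur; these two steps give one, and it is the same from compound 2 and from compound 3. Nothing in the available data accounts for this drop.

An oxygen or a methylene in place of the sulfur would help show whether the lower number follows loss of the sulfur or this particular entering group. Going by these compounds, whether the same step holds with the bromine-bearing compound 1 also remains open.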